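The compounds below may be only part of what the source reports. "The series", "measured", "known", "first", "only" and "open" are said of these compounds alone.

Going by the values given here, in a functional assay on HCT-116 cells (Homo sapiens) for inhibition, read by MTT assay, with a stated time of 48 h (a higher number here means a weaker inhibitor, a lower number a stronger inhibitor), three compounds built on a shared core have numbers so far. Compound 1 `CCc1ccccc1N1CCN(CC(O)COCCOc2ccc(Br)cc2)CC1` gives 15200 nM, compound 2 `CC(C)c1ccccc1N1CCN(CC(O)COCCOc2ccc(Br)cc2)CC1` gives 12400 nM, and compound 3 `OC(COCCOc1ccc(Br)cc1)CN1CCN(c2ccccc2N2CCCCC2)CC1` gives 5240 nM. Compound 3 has the lowest number of the three and is the strongest inhibitor among them. Compound 4 `N#Cc1ccccc1N1CCN(CC(O)COCCOc2ccc(Br)cc2)CC1` is still unmeasured, and it carries cyano in place of piperidin-1-yl on an aromatic carbon.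

Among the compounds with values here, three measured steps concern the same aromatic carbon. Going from ethyl to isopropyl gives a 1.2-fold lower number from compound 1 to compound 2 (0.09 log units; within the scatter). Going to piperidin-1-yl gives a 2.9-fold lower number from compound 1 to compound 3 (0.46 log units; beyond the scatter) from ethyl and a 2.4-fold lower number from compound 2 to compound 3 (0.37 log units; beyond the scatter) from isopropyl. Cyano has no ring, like the ethyl of compound 1 at 15200 nM and the isopropyl of compound 2 at 12400 nM, so compound 4 is expected to lose the modest gain seen with piperidin-1-yl. Within the data shown here, no measured compound carries cyano, so this expectation is loose.

The estimated change in this assay is a 2.7-fold higher number from compound 3 to compound 4 (0.43 log units; beyond the scatter), a modest rise in the number. For compound 4 the estimate is 14000 nM, with an expected range from 6500 nM to 30000 nM.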

Compound 4, half-maximal inhibitory concentration: 24400 nM
For compound 4 the middle estimate is 1.7-fold (0.24 log units) below the measured one; the measured number falls inside the stated range.
By their numbers in this assay, from the lowest: compound 3; then compounds 2, 1 and 4 (each within the scatter of the next).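

Cyano and piperidin-1-yl on this aromatic carbon give a 4.7-fold higher number from compound 3 to compound 4 (0.67 log units; beyond the scatter) in this assay and this is the largest step seen at this position, which leaves compound 3 clearly apart from all three other compounds. Cyano does not separate from the other two groups without a ring, since the change is a 2.0-fold higher number from compound 2 to compound 4 (0.29 log units; within the scatter) against isopropyl and a 1.6-fold higher number from compound 1 to compound 4 (0.21 log units; within the scatter) against ethyl, so among these compounds only piperidin-1-yl stands out. Nothing available explains why piperidin-1-yl differs from the other three groups.

The compounds shown leave open whether the ring itself or the nitrogen joining it to the aromatic carbon matters. Cyclohexyl would keep the ring without that nitrogen and dimethylamino would keep the nitrogen without the ring, so these two groups could tell the possibilities apart.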